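The source may report more compounds than this note shows. Statements on the series, on what has been measured and on what is new or still open speak of the compounds shown alone.

Measured so far in a functional assay on MCF7 cells (Homo sapiens) for antiproliferative activity, read by MTT assay, with a stated time of 72 h; a lower number here means a stronger inhibitor, a higher number a weaker inhibitor:
compound 1 `CCN1CCN(c2cc(C)c3cc(NC(=O)c4cccc(Cl)c4)ccc3n2)CC1`: 3820 nM
compound 2 `Cc1cc(NCCN2CCN(C)CC2)nc2ccc(NC(=O)c3ccc(Cl)c(Cl)c3)cc12`: 1700 nM
compound 3 `CCc1ccc(C(=O)Nc2ccc3nc(N4CCN(CC)CC4)cc(C)c3c2)cc1`: 3060 nM

On these three numbers compound 3 stands second highest. Its nearest neighbour is compound 1, whose number is higher, and the gap between compound 1 and compound 3 is within the scatter; compound 2 gives the lowest number, but its distance from compound 3 is also within the scatter, so the three measured compounds cannot be ranked against one another on this assay.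

Compound 4 `CCN1CCN(c2cc(C)c3cc(NC(=O)c4ccc(Cl)cc4)ccc3n2)CC1` is not yet measured. It differs from compound 3 in one place: chloro in place of ethyl on an aromatic carbon. The change sits on an aromatic carbon of a six-membered aromatic ring of carbon only, para to a large group.

Within the data shown here, only one measured step touches the same ring: a 1.2-fold lower number from compound 1 to compound 3 (0.10 log units; within the scatter). That step swapped a chloro for an ethyl, though at a different position, and it did not move the number beyond the scatter. Among the measured compounds shown here, no measured pair gives the chloro-for-ethyl exchange at the position of compound 4 directly, and compound 2 changes elsewhere as well, so it does not bear on this step.

The expectation for compound 4 is therefore a step of a 1.0-fold lower number from compound 3 to compound 4 (0.01 log units; within the scatter) with no direction beyond the scatter. Compound 4 is estimated at 3000 nM, with a range from 1200 nM to 7500 nM.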

Compound 4, half-maximal inhibitory concentration: 1530 nM
Compound 4: the middle estimate sits 2.0-fold (0.29 log units) above what was measured; the measured number falls inside the stated range.
By their numbers in this assay, from the lowest: compounds 4, 2, 3 and 1 (each within the scatter of the next, the first and the last beyond it).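

On the phenyl ring carried by the carbonyl, this assay now gives its first step beyond the scatter, a 2.5-fold lower number from compound 1 to compound 4 (0.40 log units; beyond the scatter), a modest one in which only the place of the chlorine differs, 4-chlorophenyl standing in for 3-chlorophenyl. The exchange at the position para to a large group gives a 2.0-fold lower number from compound 3 to compound 4 (0.30 log units; within the scatter), which stays within the scatter, so ethyl and chloro cannot be told apart there, and compound 3 cannot be separated from either compound 1 or compound 4 on this read-out. No measurement at hand accounts for either step.

A 3-ethylphenyl would complete the set of ethyl and chloro at both ring positions, and only then could the place of a group be read apart from its kind. As far as these compounds go, whether a 4-methoxyphenyl, a 4-fluorophenyl or an unsubstituted phenyl on the carbonyl falls nearer compound 4 or compound 1 remains open, as does whether the difference between the two chlorophenyl isomers holds with a different amine on the shared core.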